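Methyl on the imidazole ring: an unreadable step

The compounds below may be only part of what the source reports. "The series", "measured", "known", "first", "only" and "open" are said of these compounds alone.

Measured compounds in a functional assay on the whole organism for agonist activity, with Mus musculus as the target; a higher number here means that more compound is needed for the effect, a lower number that less compound is needed:
compound 1, `CC(=O)NCC#CCn1ccnc1`, > 100 mg/kg
compound 2, `CC(=O)NCC#CCn1cncc1C`, > 100 mg/kg
compound 3, `CCOC(=O)N(C)C(C)C#CCn1ccnc1`, > 100 mg/kg

Each of these values is a limit of this assay, not a number. Compound 1 reaches only a limit. Compound 2 likewise reaches only a limit. Compound 3 too sits at a limit. The step that the two limits leave unreadable from compound 1 to compound 2 is the change (methyl in place of hydrogen on an aromatic carbon); its size cannot be read, because the limit of > 100 mg/kg in this assay, at which 3 of the 3 values shown sit, holds all three values. The difference between the cores of compound 1 and compound 3 is not broken down here.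

Compound 4, `CCOC(=O)N(C)C(C)C#CCn1cncc1C`, is not yet measured. It differs from compound 3 by methyl in place of hydrogen on an aromatic carbon, the same kind of change as from compound 1 to compound 2, though the ring atom next to the place carries a large group rather than a group of 8 heavy atoms. Among the compounds with values here, because the limit of > 100 mg/kg in this assay, at which 3 of the 3 values shown sit, is where every value so far sits, the step that the limit leaves unreadable from compound 3 to compound 4 is expected to be unreadable in the same way. Compound 4 is therefore estimated at 150 mg/kg in this assay, most probably again as a limit.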

Compound 4, dose for half-maximal effect: > 100 mg/kg
Compound 4: a limit, no number; the forecaster's own chance of this, stated with the estimate: 90%; the middle value does not contradict the limit.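

No size can be read for the change from compound 3 to compound 4, because both stand at a limit and not at a number: the limit of > 100 mg/kg in this assay, at which 4 of the 4 values shown sit.

The compounds shown leave open what dose any of them would need in this assay and how large the methyl step really is.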